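This account rests on a few compounds, and the source may have more. Where it says the series, first, only, none or still open, it means among the compounds named here.

Among the measured compounds shown here, compound 3, `COc1ccc(CN(C(=O)CSc2nc3ccccc3s2)c2cc(OC)c(OC)c(OC)c2)cc1F`, is one of three compounds measured in a functional assay on HCT-116 cells (Homo sapiens) for antiproliferative activity, read by MTT assay, with a stated time of 48 h; a higher number here means a weaker inhibitor, a lower number a stronger inhibitor. Compound 3 gives 1830 nM. It stands second highest of the three numbers: compound 2, `COc1ccc2nc(SCC(=O)N(Cc3ccc(OC)c(O)c3)c3cc(OC)c(OC)c(OC)c3)sc2c1`, gives 352 nM, the lowest of the set, while compound 1, `COc1cc(N(Cc2ccccc2)C(=O)CSc2nc3ccccc3s2)cc(OC)c1OC`, gives 54500 nM, the highest. For the measured compounds named here, the only single-point step among them runs from compound 1 to compound 3, where there is a 30-fold lower number from compound 1 to compound 3 (1.47 log units; beyond the scatter).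

Compound 4, `COc1cc(N(Cc2ccc(F)cc2)C(=O)CSc2nc3ccccc3s2)cc(OC)c1OC`, has not yet been measured in this assay. It differs from compound 3 in one place: 4-fluorophenyl in place of 3-fluoro-4-methoxyphenyl on a saturated chain carbon bound to an amide-type nitrogen. Compound 4 thus sits between compound 1 and compound 3, keeping part of what was added in the step from compound 1 to compound 3 and giving up the rest. That step is the only one that bears on the change, and it was large. Because of a 30-fold lower number from compound 1 to compound 3 (1.47 log units; beyond the scatter), the number for compound 4 is expected to rise back toward that of compound 1, though not fully, since 4-fluorophenyl retains one substituent; the expected step is a 4.4-fold higher number from compound 3 to compound 4 (0.64 log units; beyond the scatter). Compound 4 is estimated at 8000 nM, with a range from 2500 nM to 30000 nM.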

Compound 4, half-maximal inhibitory concentration: 59800 nM
For compound 4 the middle estimate is 7.5-fold (0.87 log units) below the measured one; measured number above the stated range.
By their numbers in this assay, from the lowest: compound 2; then compound 3; then compounds 1 and 4 (each within the scatter of the next).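

In this assay fluoro alone carries none of the gain: fluoro in place of hydrogen on an aromatic carbon gives a 1.1-fold higher number from compound 1 to compound 4 (0.04 log units; within the scatter) and leaves the number where it was. By contrast, 4-fluorophenyl in place of 3-fluoro-4-methoxyphenyl gives a 33-fold higher number from compound 3 to compound 4 (1.51 log units; beyond the scatter) and hands back about as much as a 30-fold lower number from compound 1 to compound 3 (1.47 log units; beyond the scatter) had gained. On this saturated chain carbon bound to an amide-type nitrogen, the gain therefore goes with the whole 3-fluoro-4-methoxyphenyl group and is not reached through fluoro alone.

From the compounds shown here alone, it remains open whether methoxy on the phenyl ring would carry the gain by itself or only together with the fluoro, and what an ethoxy or an amine would do in its place. Nothing measured here gives a reason for the size of these steps.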